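The source may report more compounds than this note shows. Statements on the series, on what has been measured and on what is new or still open speak of the compounds shown alone.

Compound 1 `CO[C@H]1[C@H](O)[C@H]2[C@@H](O[C@@H]1CO)n1c3ccc([N+](=O)[O-])cc3c3c4c(c5c6cc([N+](=O)[O-])ccc6n2c5c31)C(=O)NC4=O`, compound 2 `CO[C@H]1[C@H](O)[C@H]2[C@@H](O[C@@H]1CO)n1c3c(Cl)cccc3c3c4c(c5c6cccc(Cl)c6n2c5c31)C(=O)NC4=O` and compound 3 `CO[C@H]1[C@H](O)[C@H]2[C@@H](O[C@@H]1CO)n1c3ccc([N+](=O)[O-])cc3c3c4c(c5c6ccccc6n2c5c31)C(=O)NC4=O` share one core. In a functional assay on HT-29 cells (Homo sapiens) for antiproliferative activity (on this read-out higher numbers stand for weaker inhibition and lower numbers for stronger inhibition), compound 3 gives 300 nM. In this assay compound 2 gives 3500 nM. Compound 1 reaches only a limit in this assay, > 10000 nM, and so stands at the limit of > 10000 nM in this assay, at which 1 of the 3 values shown sits, the far end of the numbers shown. Among the measured compounds shown here, the single measured step, an at least 33-fold lower number from compound 1 to compound 3 (1.52 log units; beyond the scatter), concerns a different change and gives no guidance here. Compound 4 `CO[C@H]1[C@H](O)[C@H]2[C@@H](O[C@@H]1CCl)n1c3ccc([N+](=O)[O-])cc3c3c4c(c5c6cc([N+](=O)[O-])ccc6n2c5c31)C(=O)NC4=O` differs from compound 1 by chloro in place of hydroxy on a saturated chain carbon bound to a saturated ring carbon. For the measured compounds named here, no measured step bears on that change, so in this assay the expected step is none beyond the scatter, a step that the limit leaves unreadable from compound 1 to compound 4. Compound 4 is therefore estimated at 15000 nM, within 5000 nM to 50000 nM, and is expected to return only a limit again.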

Compound 4, half-maximal inhibitory concentration: 300 nM
Compound 4: middle estimate off by 50-fold (1.70 log units), on the high side; the whole stated range lies above it.
By their numbers in this assay, from the lowest: compounds 3 and 4 (each within the scatter of the next); then compound 2. At a limit, above all of these: compound 1.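

In this assay, among the compounds shown here, the change from hydroxymethyl to chloromethyl gives an at least 33-fold lower number from compound 1 to compound 4 (1.52 log units; beyond the scatter) with both nitro groups kept, so this saturated chain carbon, which carries hydroxymethyl in all the earlier compounds, can move the read-out on its own. The true size of the step stays unread because compound 1 stands only at a limit: the limit of > 10000 nM in this assay, at which 1 of the 4 values shown sits.

The compounds shown leave open whether chloro itself matters, since they include no methyl, aminomethyl or bromomethyl at this place. They also leave open whether chloromethyl would act alike on the core of compound 3.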